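Amide series: from oxan-4-yl to benzoyl on the carbonyl

The source may hold more compounds than are shown below. What is called first, only, known or untested is meant among the compounds shown, and "the series" means these compounds.

Working notes on the amides built on the core of compound 1 `Cc1cc(NC(=O)C(C)C)nn1Cc1cc(Cl)ccc1OCc1ccccc1`. In a physicochemical assay for lipophilicity, at pH 7.4 (a higher number here means a more lipophilic compound, a lower number a more polar compound), compound 1 gives > 3.7, a limit of the assay rather than a number. Compound 2 `Cc1cc(NC(=O)C2CCCC2)nn1Cc1cc(Cl)ccc1OCc1ccccc1` gives 3.5 in this assay. Compound 3 `Cc1cc(NC(=O)C2CCOCC2)nn1Cc1cc(Cl)ccc1OCc1ccccc1` gives > 3.7, again a limit, so compound 3 stands only on a range; this is the limit of > 3.7 in this assay, at which 2 of the 3 values shown sit. The measured steps read a number at least 0.20 log units lower from compound 1 to compound 2 (that floor lies within the scatter), a number at least 0.20 log units higher from compound 2 to compound 3 (that floor lies within the scatter) and a step that the two limits leave unreadable from compound 1 to compound 3.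

Compound 4 `Cc1cc(NC(=O)c2ccccc2)nn1Cc1cc(Cl)ccc1OCc1ccccc1` carries phenyl in place of oxan-4-yl on a carbonyl carbon. Within the data shown here, no measured step exchanges oxan-4-yl for phenyl; the nearest, a number at least 0.20 log units higher from compound 2 to compound 3 (that floor lies within the scatter), supplies only a floor. The step that the limit leaves unreadable from compound 3 to compound 4 in this assay is expected to be upward. Compound 4 is estimated at 4.5, between 3.9 and 5.2, most likely reported again as a limit.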

Compound 4, distribution coefficient: > 3.7
Compound 4 was reported as a limit; the forecaster's own chance of this, stated with the estimate: 85%; the middle value lies beyond the limit too.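

Against cyclopentyl, phenyl on the carbonyl carbon gives a number at least 0.20 log units higher from compound 2 to compound 4 (that floor lies within the scatter), the same floor that oxan-4-yl gave. In this assay compound 4 gives > 3.7, a limit of the assay. The steps among the compounds at that limit cannot be read, so an aromatic ring of carbon only and a non-aromatic ring with one hetero atom are not told apart at this position: the limit of > 3.7 in this assay, at which 3 of the 4 values shown sit.

Still open, going by these compounds, is whether an amine or a carboxylic acid on the carbonyl carbon would give a number rather than this limit. On these data alone, the order of phenyl, oxan-4-yl and isopropyl also stays open.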